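From Ethoxy to Isopentyloxy: Expecting Compound 4

The source may report more compounds than this note shows. Statements on the series, on what has been measured and on what is new or still open speak of the compounds shown alone.

Of the compounds shown here, three that share one core have been tested in a functional assay on KB cells (Homo sapiens) for cytotoxicity, read by MTT assay, with a stated time of 72 h; a higher number here means a weaker inhibitor, a lower number a stronger inhibitor. Compound 1 `CCCCCOCNc1n[n+]([O-])c2ccccc2[n+]1[O-]` gives 1220 nM. Compound 2 `COc1ccc(COCNc2n[n+]([O-])c3ccccc3[n+]2[O-])cc1` gives 4060 nM. Compound 3 `CCOCNc1n[n+]([O-])c2ccccc2[n+]1[O-]` gives 2800 nM, the second highest of the three numbers: its gap to compound 2 lies within the scatter, while the step of a 2.3-fold higher number from compound 1 to compound 3 (0.36 log units; beyond the scatter) lies beyond it.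

Compound 4 `CC(C)CCOCNc1n[n+]([O-])c2ccccc2[n+]1[O-]` differs from compound 3 in one place: isopropyl in place of hydrogen on a saturated chain carbon, two bonds along the chain from an oxygen on a saturated carbon. Put another way, the ethoxy of compound 3 becomes isopentyloxy.

The measured step that bears on this runs in the opposite direction, a 2.3-fold higher number from compound 1 to compound 3 (0.36 log units; beyond the scatter), where hydrogen took the place of propyl at the same carbon and the number rose modestly. Compound 4 restores a chain of comparable length to that of compound 1, so a modest drop in the number is expected, roughly undoing that step. The estimate for compound 4 in this assay is 1300 nM, within 600 nM to 2800 nM, meaning an expected step of a 2.2-fold lower number from compound 3 to compound 4 (0.33 log units; beyond the scatter).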

Compound 4, half-maximal inhibitory concentration: 3040 nM
Compound 4: the middle estimate sits 2.3-fold (0.37 log units) below what was measured; measured number above the stated range.
By their numbers in this assay, from the lowest: compound 1; then compounds 3, 4 and 2 (each within the scatter of the next).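

Adding isopropyl in place of hydrogen at this carbon leaves the number in this assay where it was (a 1.1-fold higher number from compound 3 to compound 4 (0.04 log units; within the scatter)), so a longer chain alone does not bring the lower number of compound 1. The sharper contrast is at the same carbon, with isopropyl in place of propyl (a 2.5-fold higher number from compound 1 to compound 4 (0.40 log units; beyond the scatter)), which shows that the two chain ends are not interchangeable here. Isobutyl and 4-methoxyphenyl, the groups on the carbon bound to the oxygen, also cannot be told apart (a 1.3-fold lower number from compound 2 to compound 4 (0.13 log units; within the scatter)), leaving compound 1 alone with a clearly lower number than the other three.

As far as these compounds go, whether a longer straight chain or an amine at the chain end would keep or lower that number stays open. Nothing shown here gives a reason for the difference between propyl and isopropyl at this carbon.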